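This account rests on a few compounds, and the source may have more. Where it says the series, first, only, none or still open, it means among the compounds named here.

Compound 1 `CC1=CC[C@H](C(C)(C)NC(=S)N/N=C/c2ccc(F)cc2)CC1` and compound 2 `CC1=CC[C@H](C(C)(C)NC(=S)N/N=C/c2ccc(Cl)cc2)CC1` share one core and differ only in the halogen carried on the aromatic ring. In a functional assay on UACC-62 cells (Homo sapiens) for inhibition, read by sulforhodamine B assay, with a stated time of 48 h (on this read-out higher numbers stand for weaker inhibition of growth and lower numbers for stronger inhibition of growth), compound 1 gives only the limit > 100000 nM. Compound 2 likewise gives only the limit > 100000 nM in this assay. The change from fluoro to chloro is therefore a step that the two limits leave unreadable from compound 1 to compound 2, since both values sit at the limit of > 100000 nM in this assay, at which 2 of the 2 values shown sit. Compound 3 `CC1=CC[C@H](C(C)(C)NC(=S)N/N=C/c2cccs2)CC1` carries thiophen-2-yl in place of 4-chlorophenyl on a carbon with a double bond to nitrogen. Going by the values given here, with the only measured step unreadable, the expected step is a step that the limit leaves unreadable from compound 2 to compound 3 in this assay, with no direction that can be read. Compound 3 is thus estimated at 150000 nM, between 40000 nM and 500000 nM.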

Compound 3, concentration for total growth inhibition: 19000 nM
For compound 3 the middle estimate is 7.9-fold (0.90 log units) above the measured one; measured number outside the range, below it.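

In this assay, the group on a carbon with a double bond to nitrogen clearly matters: thiophen-2-yl in place of 4-chlorophenyl gives an at least 5.2-fold lower number from compound 2 to compound 3 (0.72 log units; beyond the scatter), and thiophen-2-yl in place of 4-fluorophenyl gives an at least 5.2-fold lower number from compound 1 to compound 3 (0.72 log units; beyond the scatter). Going by these compounds alone, these are the first readable steps here, as the swap of one halogen for the other could not be read. Their full size stays unknown, since each starts from a limit: the limit of > 100000 nM in this assay, at which 2 of the 3 values shown sit.

As far as these compounds go, it remains open whether the ring sulfur or the smaller ring counts, which a furan-2-yl or an unsubstituted phenyl group at this place could help to separate.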